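Solubility notes on a dimethylaminophenyl analogue

The source may hold more compounds than are shown below. What is called first, only, known or untested is meant among the compounds shown, and "the series" means these compounds.

Compound 2 `Cc1noc(-c2nc(C)c3c(c2N)C(=O)N(Cc2ccc(Cl)cn2)C3=O)n1` sits at a limit in a physicochemical assay for solubility, using the shake flask method, in simulated intestinal fluid, measured as kinetic solubility, with a stated time of 2 h, at 25 degrees C, at pH 6.5 (on this read-out lower numbers stand for lower solubility and higher numbers for higher solubility), giving < 5000 nM. Compound 1 `Cc1noc(-c2nc(C)c3c(c2N)C(=O)N(Cc2cccc(C(F)(F)F)c2)C3=O)n1` likewise gives only a limit, < 5000 nM. The step that the two limits leave unreadable from compound 1 to compound 2 is therefore unreadable, with both values resting at the limit of < 5000 nM in this assay, at which 2 of the 2 values shown sit. Compound 3 `Cc1noc(-c2nc(C)c3c(c2N)C(=O)N(Cc2ccc(N(C)C)cc2)C3=O)n1` carries the change (4-(dimethylamino)phenyl in place of 5-chloropyridin-2-yl on a saturated chain carbon bound to an amide-type nitrogen in a ring). Among the measured compounds shown here, no measured step informs this exchange, as the single comparable step is a limit on both sides, so no direction beyond the scatter is expected; compound 3 is expected to remain near the limit. The estimate for compound 3 is 3000 nM, within 500 nM to 15000 nM. The expected step is a step that the limit leaves unreadable from compound 2 to compound 3.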

Compound 3, solubility: 7400 nM
Estimate against measurement, compound 3: 2.5-fold (0.39 log units) below, and the stated range covers the measured number.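

Among the compounds shown here, on a saturated chain carbon bound to an amide-type nitrogen in a ring, 4-(dimethylamino)phenyl gives the first number in this assay that is not a limit. The exchanges give an at least 1.4-fold higher number from compound 2 to compound 3 (0.17 log units; that floor lies within the scatter) and an at least 1.4-fold higher number from compound 1 to compound 3 (0.17 log units; that floor lies within the scatter). Both are floors only, resting on the limit of the assay: the limit of < 5000 nM in this assay, at which 2 of the 3 values shown sit.

From the compounds shown here alone, the true size of either step stays open, as does whether the dimethylamino group or the carbon-only ring accounts for the reading. Also open, going by these compounds, is how a morpholine, a carboxylic acid or an unsubstituted phenyl would read at this place.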